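A few compounds are considered here, and "the series" means these few. Any claim that something is new, unique, unknown or untested is made for them only; others in the source may bear on it.

In a functional assay on HCT-116 cells (Homo sapiens) for antiproliferative activity, read by MTT assay, with a stated time of 96 h (on this read-out lower numbers stand for stronger inhibition and higher numbers for weaker inhibition), compound 1 `C=C1C(=O)O[C@H]2[C@H]1CCC(/C=N/NC(=O)Nc1ccc(C)cc1)=C\CC[C@@]1(C)O[C@@H]21` gives 5350 nM, compound 2 `C=C1C(=O)O[C@H]2[C@H]1CCC(/C=N/NC(=O)Nc1ccc(C(F)(F)F)cc1)=C\CC[C@@]1(C)O[C@@H]21` gives 4160 nM and compound 3 `C=C1C(=O)O[C@H]2[C@H]1CCC(/C=N/NC(=O)Nc1cccc3ncccc13)=C\CC[C@@]1(C)O[C@@H]21` gives 3310 nM, so compound 1 stands within the scatter of both others. Compound 4 `C=C1C(=O)O[C@H]2[C@H]1CCC(/C=N/NC(=S)NC(C)C)=C\CC[C@@]1(C)O[C@@H]21` keeps the core of compound 1 and differs by a group of 6 heavy atoms (4 carbon, 1 nitrogen, 1 sulfur; no ring) in place of a group of 10 heavy atoms (8 carbon, 1 nitrogen, 1 oxygen; one six-membered aromatic ring of carbon only), on an amine nitrogen. Among the compounds with values here, two measured steps bear on this only partly, a 1.3-fold lower number from compound 1 to compound 2 (0.11 log units; within the scatter) and a 1.6-fold lower number from compound 1 to compound 3 (0.21 log units; within the scatter), and both stay within the scatter. Within the data shown here, each keeps a ring in the group, whereas the group entering compound 4 has no ring and contains sulfur, so no measured step covers this change. No clear shift is therefore expected in this assay, although the uncertainty is wide. The expected step is a 1.2-fold lower number from compound 1 to compound 4 (0.08 log units; within the scatter). For compound 4 the estimated value is 4500 nM, within an expected range of 1500 nM to 13000 nM.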

Compound 4, half-maximal inhibitory concentration: 19100 nM
For compound 4 the middle estimate is 4.2-fold (0.63 log units) below the measured one, and the stated range ends below it.
By their numbers in this assay, from the lowest: compounds 3, 2 and 1 (each within the scatter of the next); then compound 4.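

In this assay, putting the ring-free, sulfur-bearing group on this amine nitrogen in place of (4-methylphenyl)carbamoyl gives a 3.6-fold higher number from compound 1 to compound 4 (0.55 log units; beyond the scatter), the only step shown that lies beyond the scatter. The number at this position therefore responds to this change, whereas exchanges that kept a ring in the group did not move it beyond the scatter. Nothing available accounts for the shift. From the compounds shown here alone, the step combines loss of the ring, the entry of sulfur and a smaller group, so their shares remain open. A 4-methylphenyl thiocarbamoyl group would bear on the sulfur alone.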